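The source may report more compounds than this note shows. Statements on the series, on what has been measured and on what is new or still open speak of the compounds shown alone.

Among the compounds with values here, in a functional assay on MDA-MB-231 cells (Homo sapiens) for antiproliferative activity, with a stated time of 4 days (on this read-out lower numbers stand for stronger inhibition and higher numbers for weaker inhibition), compound 1 `COc1ccc(-c2[nH]c3ccc(OC)cc3c2C=O)cc1` gives 260 nM, the highest of the three numbers so far. Compound 2 `COc1ccc(-c2[nH]c3cc(OC)ccc3c2C=O)cc1` gives 35 nM and compound 3 `CCCCc1ccc2[nH]c(-c3ccc(OC)cc3)c(C=O)c2c1` gives 6.7 nM, both lower beyond the scatter. The unmeasured compound 4 `COc1ccc(-c2[nH]c3ccc(C(C)(C)C)cc3c2C=O)cc1` has tert-butyl in place of methoxy on an aromatic carbon of the core of compound 1: tert-butyl in place of methoxy on an aromatic carbon. Within the data shown here, the one measured step that bears on this change is butyl in place of methoxy on an aromatic carbon, a 39-fold lower number from compound 1 to compound 3 (1.59 log units; beyond the scatter), which is large and beyond the scatter. Among the measured compounds shown here, compound 2 offers no such step. That single precedent involves a different four-carbon group, so its full size cannot simply be carried over. A large step towards stronger inhibition in this assay is still expected, and the estimated change is a 17-fold lower number from compound 1 to compound 4 (1.24 log units; beyond the scatter). For compound 4, the expected value is 15 nM, with an estimated range from 4 nM to 60 nM.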

Compound 4, half-maximal inhibitory concentration: 280 nM
Beside the measured number, compound 4's estimate is 19-fold (1.27 log units) below it, and the stated range ends below it.
By their numbers in this assay, from the lowest: compound 3; then compound 2; then compounds 1 and 4 (each within the scatter of the next).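

In this assay tert-butyl in place of methoxy gives a 1.1-fold higher number from compound 1 to compound 4 (0.03 log units; within the scatter) and so leaves the number within the scatter, while tert-butyl in place of butyl on the same aromatic carbon gives a 42-fold higher number from compound 3 to compound 4 (1.62 log units; beyond the scatter) and is a large step. The low number of compound 3 therefore does not come simply from methoxy leaving this position, nor does it carry over to every alkyl group placed there; across these three compounds, only butyl stands apart from the other two groups. Nothing measured here accounts for the gap between butyl and tert-butyl.

The compounds shown leave open whether a propyl group or a longer chain such as hexyl at this position would read like butyl or like tert-butyl. They also leave open how an amine or a carboxylic acid would behave on this same aromatic carbon.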